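Swapping fluoro for dimethylcarbamoyl on the fused ring

The source may hold more compounds than are shown below. What is called first, only, known or untested is meant among the compounds shown, and "the series" means these compounds.

Measured compounds:
compound 1 `O=C(O)CCc1ccc(OCC2COc3cc(Br)ccc3O2)cc1F` gives 980 nM
compound 2 `CC#C[C@H](CC(=O)O)c1ccc(OC[C@H]2COc3ccc(Cl)cc3O2)cc1` gives 3400 nM
compound 3 `CC#C[C@@H](CC(=O)O)c1ccc(OC[C@H]2COc3ccc(F)cc3O2)cc1` gives 210 nM

All three were tested in a functional assay on HEK293 cells for agonist activity at Free fatty acid receptor 1 (Homo sapiens), read by fluorescence and calcium flux, with a stated time of 10 min; a lower number here means that less compound is needed, a higher number that more compound is needed for the effect. Among them compound 3 stands lowest, needing the least compound for the effect; compound 1 lies well beyond the scatter above it, and compound 2 lies further still. The three differ at several places at once, so no single change can be read from them.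

Compound 4 `CC#C[C@@H](CC(=O)O)c1ccc(OC[C@H]2COc3ccc(C(=O)N(C)C)cc3O2)cc1` has not yet been measured. It differs from compound 3 in one place: dimethylcarbamoyl in place of fluoro on an aromatic carbon. Going by the values given here, nothing among the measured compounds shows what a dimethylcarbamoyl group does on that fused ring, so there is no step to lean on. The expectation is a modest move toward a higher number, perhaps no larger than the scatter, rather than a loss of the kind seen between compound 3 and compound 2. Compound 4 is therefore estimated at 450 nM, within a range from 120 nM to 1800 nM, an expected step of a 2.1-fold higher number from compound 3 to compound 4 (0.33 log units; beyond the scatter).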

Compound 4, half-maximal effective concentration: > 30000 nM
Compound 4: only a limit was reported (the forecaster's own chance of this, stated with the estimate: 3%); middle value at least 66-fold (1.82 log units) from the limit.
By their numbers in this assay, from the lowest: compound 3; then compound 1; then compound 2. At a limit, above all of these: compound 4.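

Read in this assay, dimethylcarbamoyl in place of fluoro on this aromatic carbon gives an at least 140-fold higher number from compound 3 to compound 4 (2.15 log units; beyond the scatter), the first single-place change in this set. Going by these compounds alone, compound 4 has a limit rather than a measured number, so the true step could be larger: the limit of > 30000 nM in this assay, at which 1 of the 4 values shown sits. The earlier compounds carry only a single halogen atom on this fused ring, whereas this result shows that the position does not accept every replacement for fluoro, since a group of five heavy atoms with one hydrogen-bond acceptor leaves no response that can be given a number.

Which part of dimethylcarbamoyl matters remains open, whether the carbonyl or the two methyl groups. A nitrile, a methoxy group or an unsubstituted carboxamide on the same carbon would help to separate these possibilities.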